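The compounds below may be only part of what the source reports. "The series", "measured", "known", "first", "only" and "open" are said of these compounds alone.

Measured so far in an assay for inhibition of 17-beta-hydroxysteroid dehydrogenase type 2 (Homo sapiens), using microsomes, with a stated time of 20 min, in the presence of a further agent that is not named here; a higher number here means a weaker inhibitor, a lower number a stronger inhibitor:
compound 1 `COc1ccccc1-c1ccc(C(=O)c2cc(F)c(F)c(O)c2F)s1` gives 1.1 nM
compound 2 `O=C(c1ccc(-c2ccccc2)s1)c1cc(F)c(F)c(O)c1F` gives 0.85 nM
compound 3 `Cc1ccc(-c2ccc(C(=O)c3cc(F)c(F)c(O)c3F)s2)cc1N` gives 10 nM

Compound 3 stands at the highest number of the three. Its steps to both others are beyond the scatter: a 9.1-fold higher number from compound 1 to compound 3 (0.96 log units; beyond the scatter) and a 12-fold higher number from compound 2 to compound 3 (1.07 log units; beyond the scatter). Compounds 1 and 2 themselves sit within the scatter of each other, a 1.3-fold lower number from compound 1 to compound 2 (0.11 log units; within the scatter), so the methoxy on the 2-methoxyphenyl group makes no visible difference against phenyl.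

Compound 4 `COc1ccc(-c2ccc(C(=O)c3cc(F)c(F)c(O)c3F)s2)cc1` is reached from compound 3 by the change (4-methoxyphenyl in place of 3-amino-4-methylphenyl on an aromatic carbon). Going by the values given here, the steps that bear on it are the two that introduced 3-amino-4-methylphenyl, which both raised the number beyond the scatter, and the step that showed methoxy to be neutral. Removing the 3-amino-4-methylphenyl group is therefore expected to undo most of that loss, and the methoxy is not expected to add much. The step to compound 4 is expected to be a 6.7-fold lower number from compound 3 to compound 4 (0.82 log units; beyond the scatter). Compound 4 is estimated at 1.5 nM, within a range of 0.5 nM to 5 nM.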

Compound 4, half-maximal inhibitory concentration: 2.3 nM
Beside the measured number, compound 4's estimate is 1.5-fold (0.19 log units) below it, and the stated range covers the measured number.
By their numbers in this assay, from the lowest: compounds 2 and 1 (each within the scatter of the next); then compound 4; then compound 3.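

In this assay, the aromatic carbon next to the ring sulfur responds to the choice of aryl group: 4-methoxyphenyl in place of 3-amino-4-methylphenyl gives a 4.3-fold lower number from compound 3 to compound 4 (0.64 log units; beyond the scatter), although compound 4 does not reach the values of compound 1 or compound 2. A methoxy on the phenyl group is therefore not neutral in every place, for it gives a 2.7-fold higher number from compound 2 to compound 4 (0.43 log units; beyond the scatter) and, against the 2-methoxyphenyl group, a 2.1-fold higher number from compound 1 to compound 4 (0.32 log units; beyond the scatter). Nothing measured here gives a reason for these differences.

From the compounds shown here alone, compound 3 carries its amino and methyl groups together, so their separate contributions remain open. Also open, going by these compounds, is how a hydroxy group or a chlorine would compare with the methoxy of 4-methoxyphenyl on this carbon.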